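This account rests on a few compounds, and the source may have more. Where it says the series, first, only, none or still open, it means among the compounds named here.

Measured so far in an ADME assay on microsomes from liver (Rattus norvegicus) for metabolic stability, with a stated time of 10 min; on this read-out lower numbers stand for a less stable compound and higher numbers for a more stable compound:
- compound 1 `O=C(NS(=O)(=O)c1ccc(F)cc1)c1ccc(Nc2nc(NC3(c4ccc(Cl)cc4)CC3)nc(OCC(F)(F)F)n2)cc1`: 99%
- compound 2 `CC(C)(C)NC(=O)NCCS(=O)(=O)NC(=O)c1ccc(Nc2nc(NC3(c4ccc(Cl)cc4)CC3)nc(OCC(F)(F)F)n2)cc1`: 93%
- compound 3 `CCS(=O)(=O)NC(=O)c1ccc(Nc2nc(NC3(c4ccc(Cl)cc4)CC3)nc(OCC(F)(F)F)n2)cc1`: 85%

Among these three numbers compound 1 stands highest in this assay; compound 2 is nearest, the difference being a number 6 percentage points lower from compound 1 to compound 2 (within the scatter), and compound 3 furthest, with a number 14 percentage points lower from compound 1 to compound 3 (beyond the scatter). Compound 4 `COC(=O)NCCS(=O)(=O)NC(=O)c1ccc(Nc2nc(NC3(c4ccc(Cl)cc4)CC3)nc(OCC(F)(F)F)n2)cc1` has not yet been measured. It differs from compound 1 in one place: 2-((methoxycarbonyl)amino)ethyl in place of 4-fluorophenyl on a sulfonyl sulfur.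

Going by the values given here, two measured steps bear on this change. Replacing the same 4-fluorophenyl with another substituted ethyl chain gave a number 6 percentage points lower from compound 1 to compound 2 (within the scatter), while replacing it with a bare ethyl gave a number 14 percentage points lower from compound 1 to compound 3 (beyond the scatter). A similar small downward step, at most a modest one, is therefore expected for compound 4: the step from compound 1 is estimated as a number 7 percentage points lower from compound 1 to compound 4 (within the scatter), giving an expected value of 92%, likely between 82% and 99%.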

Compound 4, percent of the compound remaining: 100%
For compound 4 the middle estimate is 8 percentage points below the measured one; measured number outside the range, above it.
By their numbers in this assay, from the lowest: compounds 3, 2, 1 and 4 (each within the scatter of the next, the first and the last beyond it).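

In this assay, the ring-free 2-((methoxycarbonyl)amino)ethyl can take the place of 4-fluorophenyl on the sulfonyl sulfur without a readable change: a number 1 percentage points higher from compound 1 to compound 4 (within the scatter). Adding (methoxycarbonyl)amino to the bare ethyl chain gives a clearer difference, a number 15 percentage points higher from compound 3 to compound 4 (beyond the scatter), whereas methoxy in place of (tert-butyl)amino on the carbonyl carbon stays small, a number 7 percentage points higher from compound 2 to compound 4 (within the scatter). Nothing measured here explains these differences. Going by these compounds, how a free amine or a carboxylic acid in place of the (methoxycarbonyl)amino group would fare in this assay remains open, and so does the effect of a longer chain.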